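Swapping a methyl for hydrogen on a thiosemicarbazide nitrogen

The source may report more compounds than this note shows. Statements on the series, on what has been measured and on what is new or still open speak of the compounds shown alone.

Of the compounds shown here, two sharing one core have been measured in an in vitro assay on cells for inhibition of Amine oxidase [flavin-containing] B (Homo sapiens), read by Amplex Red, with a stated time of 15 min, tested at 100 uM; on this read-out higher numbers stand for more inhibition at the one concentration tested (going by the name of the read-out) and lower numbers for less inhibition. Compound 1, `CC1CN(C(N)=S)N=C1c1ccc(F)cc1`, carries a fluorine on its aromatic ring and an unsubstituted amino group on the thiocarbonyl carbon; in this assay compound 1 gives 40%. Compound 2, `CNC(=S)N1CC(C)C(c2ccc(C)cc2)=N1`, carries a methyl on the aromatic ring and a methylamino group on the thiocarbonyl carbon; in this assay compound 2 gives 40%. On the numbers shown, compound 2 stands level with compound 1, the two values lying within the scatter of each other, so nothing can be said about an order between them.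

Compound 3, `Cc1ccc(C2=NN(C(N)=S)CC2C)cc1`, keeps the methyl on the aromatic ring but differs from compound 2 in one place: hydrogen in place of methyl on an amide-type nitrogen. Among the compounds with values here, no pair of measured compounds differs in only this way, so the size of this step is not known from the data. Because compound 1, which has the same amino group, gives 40%, the step is expected to be small, no change at the digits printed from compound 2 to compound 3 (within the scatter), with no clear direction beyond the scatter. Compound 3 is therefore expected to give about 40% in this assay, within a range from 25% to 55%.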

Compound 3, a percentage reported as inhibition, at one concentration (the size of the read-out at that concentration, not a potency): 40%
Compound 3: the middle estimate sits on the measured number at the digits printed; low and high end bracket the measured number.
By their numbers in this assay, from the lowest: compounds 1, 2 and 3 (each within the scatter of the next).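

In this assay, removing the methyl from the amide-type nitrogen, so that methylamino becomes amino, gives no change at the digits printed from compound 2 to compound 3 (within the scatter) and thereby puts a measured size on this single change, something compounds 1 and 2 could not do while differing in two places at once. Compound 3 also isolates the aromatic substituent, as methyl in place of fluoro on an aromatic carbon gives no change at the digits printed from compound 1 to compound 3 (within the scatter) in the same test, so neither single swap moves the reading beyond the usual spread of repeat measurements. No measurement at hand offers an explanation for these flat steps.

The compounds shown leave open whether a larger group on that nitrogen, such as an ethyl, a longer chain or a benzyl, would hold the reading where it is, and whether a methoxy or a chlorine on the aromatic carbon would do the same. Since the read-out comes from one concentration and is not a potency, they also leave open whether these compounds would separate from one another across a range of concentrations.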